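Swapping Bromo for Furan-2-yl on the Shared Core

This account rests on a few compounds, and the source may have more. Where it says the series, first, only, none or still open, it means among the compounds named here.

In an assay on CHO cells for displacement of a labelled ligand from transmembrane domain-containing protein TMIGD3 (Homo sapiens) (on this read-out lower numbers stand for stronger inhibition and higher numbers for weaker inhibition), compound 1 `CCCn1cnc2c(N)nc(NCc3ccccc3)nc21` gives 5840 nM. Compound 2 `CCCn1c(Br)nc2c(N)nc(NCc3ccccc3)nc21` gives 650 nM, and compound 3 `CCCn1c(Br)nc2c(N)nc(NCCCc3ccccc3)nc21` gives 1950 nM, the second highest of the three numbers, sitting between the other two. Two steps are known among these: a 9.0-fold lower number from compound 1 to compound 2 (0.95 log units; beyond the scatter) and a 3.0-fold higher number from compound 2 to compound 3 (0.48 log units; beyond the scatter). Compound 4 `CCCn1c(-c2ccco2)nc2c(N)nc(NCCCc3ccccc3)nc21` differs from compound 3 by one change: furan-2-yl in place of bromo on an aromatic carbon. Among the compounds with values here, no measured step tests this exact exchange; the nearest is the step of a 9.0-fold lower number from compound 1 to compound 2 (0.95 log units; beyond the scatter), which shows that a change at the same aromatic carbon can move the number markedly, but it says nothing about a furan-2-yl ring there. Compound 4 is therefore expected to give 1500 nM, with a range from 300 nM to 6000 nM. This estimate corresponds to an expected 1.3-fold lower number from compound 3 to compound 4 (0.11 log units; within the scatter).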

Compound 4, inhibition constant: 266 nM
Compound 4: middle estimate off by 5.6-fold (0.75 log units), on the high side, and the stated range ends above it.
By their numbers in this assay, from the lowest: compound 4; then compound 2; then compound 3; then compound 1.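

In this assay, furan-2-yl in place of bromo gives a 7.3-fold lower number from compound 3 to compound 4 (0.87 log units; beyond the scatter) and so shows that this aromatic carbon can carry a ring of 5 heavy atoms, not just a single atom, while the number still falls. The earlier step at this carbon, a 9.0-fold lower number from compound 1 to compound 2 (0.95 log units; beyond the scatter), compared only hydrogen with bromo, and on a different chain. Nothing measured on these compounds explains the drop.

From the compounds shown here alone, whether a phenyl ring or an amine at this carbon would do the same remains open. So does whether furan-2-yl would lower the number on the shorter chain of compound 2.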